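Cyclohexyl for Benzyl: Does Solubility Hold Again?

A few compounds are considered here, and "the series" means these few. Any claim that something is new, unique, unknown or untested is made for them only; others in the source may bear on it.

Measured so far in a physicochemical assay for solubility, with a stated time of 18 h, at pH 7.4; a lower number here means a less soluble compound, a higher number a more soluble compound:
compound 1 `COc1ccc(F)cc1CNCCCNc1ccnc2cc(CC3CCCCC3)ccc12` gives 4200 nM
compound 2 `COc1ccc(F)cc1CNCCCNc1ccnc2cc(CCc3ccccc3)ccc12` gives 4200 nM
compound 3 `COc1cccc(CNCCCNc2ccnc3cc(CCc4ccccc4)ccc23)c1O` gives 4200 nM

Two changes connect these three. Going from compound 2 to compound 1 the change is cyclohexyl in place of benzyl on a saturated chain carbon bound to an aromatic carbon, and the step is no change at the digits printed from compound 2 to compound 1 (within the scatter). Going from compound 2 to compound 3 the cores differ by 2-hydroxy-3-methoxyphenyl in place of 5-fluoro-2-methoxyphenyl on a saturated chain carbon bound to an amine nitrogen, with the step of no change at the digits printed from compound 2 to compound 3 (within the scatter).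

Compound 4 `COc1cccc(CNCCCNc2ccnc3cc(CC4CCCCC4)ccc23)c1O` is not yet measured in this assay. It differs from compound 3 by cyclohexyl in place of benzyl on a saturated chain carbon bound to an aromatic carbon, the same change as from compound 2 to compound 1, at the same place. Because that earlier step was no change at the digits printed from compound 2 to compound 1 (within the scatter), the step expected here is no change at the digits printed from compound 3 to compound 4 (within the scatter). Compound 4 is therefore estimated at 4200 nM, likely between 2000 nM and 8500 nM.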

Compound 4, solubility: 4200 nM
The estimate for compound 4 equals the measured number at the digits printed; the range from low to high includes it.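

In this assay the change of benzyl to cyclohexyl gives no change at the digits printed from compound 3 to compound 4 (within the scatter) and on the other core it gave no change at the digits printed from compound 2 to compound 1 (within the scatter), so here it carries from one core to the other with the same outcome. The change of 5-fluoro-2-methoxyphenyl to 2-hydroxy-3-methoxyphenyl likewise gives no change at the digits printed from compound 1 to compound 4 (within the scatter), whichever of the two groups stands on the saturated chain carbon bound to an aromatic carbon. Within the data shown here, this covers only two cores, so it does not show that the change would carry to any further core, and nothing measured here explains why the number stays the same.

The compounds shown leave open what a carboxylic acid or an amine in place of cyclohexyl would do. A longer chain in place of cyclohexylmethyl also remains an open case.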